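Swapping azetidin-1-yl for piperazin-1-yl on a short-lived compound

The compounds below may be only part of what the source reports. "The series", "measured", "known", "first", "only" and "open" are said of these compounds alone.

So far two compounds have been tested in an in vitro ADME assay on microsomes from liver (Rattus norvegicus) for metabolic stability; on this read-out higher numbers stand for a longer-lived compound and lower numbers for a shorter-lived compound. Compound 1 `CNc1nc(NCc2ccc(NC(=O)c3ccc(C)cc3)cc2)c2ccccc2n1` gives 0.267 h. Compound 2 `Cc1ccc2c(NCc3ccc(NC(=O)c4ccc(F)cc4)cc3)nc(N3CCC3)nc2c1` gives 0.117 h, the lower of the two numbers, and its gap to compound 1 lies beyond the usual scatter of repeated measurements. These two compounds differ in more than one place, so their gap cannot be pinned on any single group.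

Compound 3 `Cc1ccc2c(NCc3ccc(NC(=O)c4ccc(F)cc4)cc3)nc(N3CCNCC3)nc2c1` has not yet been measured. It is compound 2 with a single change: piperazin-1-yl in place of azetidin-1-yl on an aromatic carbon. Within the data shown here, no two measured compounds differ in only one place, so the data offer no direct guide to the size of this swap. The only hint comes from compound 1, whose 0.267 h shows that a longer half-life than that of compound 2 is possible among these molecules. A small rise that stays within the scatter is therefore expected, and this expectation is weakly grounded. The expected change is a 1.7-fold higher number from compound 2 to compound 3 (0.23 log units; within the scatter). For compound 3 the estimated half-life in this assay is 0.2 h, with a range of 0.08 h to 0.5 h.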

Compound 3, half-life: 0.0833 h
Beside the measured number, compound 3's estimate is 2.4-fold (0.38 log units) above it; low and high end bracket the measured number.
By their numbers in this assay, from the lowest: compounds 3 and 2 (each within the scatter of the next); then compound 1.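

In this assay, among these compounds, the swap gives the first reading of a single change, a 1.4-fold lower number from compound 2 to compound 3 (0.15 log units; within the scatter), and that step stays within the usual scatter of repeated measurements. At this position, on an aromatic carbon between two ring nitrogen atoms, a four-membered ring with one hetero atom and a six-membered ring with two hetero atoms, one of them carrying a hydrogen-bond donor, therefore cannot be told apart by half-life, even though the group has grown and gained a donor. So on this core, the added size and the extra ring nitrogen of piperazin-1-yl bring no half-life gain that can be distinguished from assay noise, and no measurement shown here offers an explanation for this outcome.

One swap on one core cannot show whether this tolerance holds for other groups at the same place, such as morpholin-4-yl, with a ring oxygen in place of the second ring nitrogen, or 4-methylpiperazin-1-yl, with a methyl group on that nitrogen. It also leaves open whether the same swap would give a similar step when the rest of the molecule differs, as it does in compound 1.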